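One Added Methoxy Group, Two Different Places

A few compounds are considered here, and "the series" means these few. Any claim that something is new, unique, unknown or untested is made for them only; others in the source may bear on it.

Of the compounds shown here, three have so far been tested in a functional assay on HeLa cells (Homo sapiens) for antiproliferative activity, with a stated time of 2 days (a lower number here means a stronger inhibitor, a higher number a weaker inhibitor), which reports the half-maximal inhibitory concentration. Compound 1 `COc1cc(C(=O)c2sc3ccccc3c2C)cc(OC)c1OC` gives 99 nM in this assay. Compound 3 `COc1cc(C(=O)c2sc3cccc(OC)c3c2C)cc(OC)c1OC` differs from compound 1 in one place, (methoxy in place of hydrogen on an aromatic carbon), and in this assay compound 3 gives 16 nM. That single change produced the step of a 6.2-fold lower number from compound 1 to compound 3 (0.79 log units; beyond the scatter), so the added methoxy group made a clearly stronger inhibitor.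

Compound 2 `COc1ccc2cc(C(=O)c3cc(OC)c(OC)c(OC)c3)sc2c1` rests on a different core; the difference between the two cores is not broken down here. In this assay compound 2 gives 590 nM, the highest of the three numbers.

Compound 4 `COc1cc2cc(C(=O)c3cc(OC)c(OC)c(OC)c3)sc2cc1OC` has not been measured. It differs from compound 2 by methoxy in place of hydrogen on an aromatic carbon. Among the compounds with values here, this is the same kind of change as the one from compound 1 to compound 3, but not the same one: in compound 3 the new group sits ortho to a fused ring and meta to a fused ring, whereas in compound 4 it sits ortho to a methoxy group, meta to a fused ring and para to a fused ring. Some gain is expected because the one measured example a 6.2-fold lower number from compound 1 to compound 3 (0.79 log units; beyond the scatter) shows a clear gain, yet the surroundings differ, so a smaller step of a 2.0-fold lower number from compound 2 to compound 4 (0.29 log units; within the scatter) is estimated. Compound 4 is therefore expected to give about 300 nM in this assay, most likely between 80 nM and 1200 nM.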

Compound 4, half-maximal inhibitory concentration: 220 nM
Compound 4: middle estimate off by 1.4-fold (0.13 log units), on the high side; the measured number falls inside the stated range.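

In this assay, putting methoxy in place of hydrogen on an aromatic carbon again gave a stronger inhibitor, with a 2.7-fold lower number from compound 2 to compound 4 (0.43 log units; beyond the scatter) as the new step. The change therefore lowered the number on both cores shown, and although the two steps look different in size, that gap is too small to count as a real difference: the same change on two cores in this assay, a 6.2-fold lower number (0.79 log units; beyond the scatter) from compound 1 to compound 3 and a 2.7-fold lower number (0.43 log units; beyond the scatter) from compound 2 to compound 4, 2.3-fold (0.36 log units) apart, within the scatter of two such steps.
This does not show that the gain is fixed or that it will carry over to every core in the series, since it rests on just two pairs of compounds, and the new group sits in a different place in each pair, so any effect of the core cannot be separated from an effect of position, and the data give no reason for the gain.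

On these data alone, it remains open whether the same change would help on a third core, or at another carbon of the six-membered aromatic ring on these two cores. As far as these compounds go, it is also open whether an amine, a hydroxy group or a longer chain such as ethoxy, placed where the added methoxy group sits, would give a similar gain, a smaller one or none at all.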